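Nitro in place of chloro: working notes on compounds 1 to 4

The source may report more compounds than this note shows. Statements on the series, on what has been measured and on what is new or still open speak of the compounds shown alone.

Measured so far in a functional assay on KB cells (Homo sapiens) for inhibition; a lower number here means a stronger inhibitor, a higher number a weaker inhibitor:
compound 1 `Clc1ccc(Cn2c(Br)nc3cc(Cl)c(Cl)cc32)cc1` gives > 100000 nM, a limit of the assay.
compound 2 `Clc1cccc(Cn2c(Br)nc3cc(Cl)c(Cl)cc32)c1` gives > 100000 nM, also a limit.
compound 3 `O=[N+]([O-])c1ccc(Cn2c(Br)nc3cc(Cl)c(Cl)cc32)cc1` gives 40000 nM.

Compound 1 and compound 2 share the same atoms joined differently; the difference between the two cores is not broken down here. Going by the values given here, the one measured step is an at least 2.5-fold lower number from compound 1 to compound 3 (0.39 log units; beyond the scatter), the change being (nitro in place of chloro on an aromatic carbon). The size of that step can only be read as a minimum because of the limit of > 100000 nM in this assay, at which 2 of the 3 values shown sit.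

Compound 4 `O=[N+]([O-])c1cccc(Cn2c(Br)nc3cc(Cl)c(Cl)cc32)c1` is not yet measured. It stands to compound 2 as compound 3 stands to compound 1, through (nitro in place of chloro on an aromatic carbon); this is the same kind of change, the place differing only in that it is "meta to a large group" rather than "para to a large group".

For compound 4 a step of an at least 2.0-fold lower number from compound 2 to compound 4 (0.30 log units; that floor lies within the scatter) in this assay is expected, resting on compound 3 and its 40000 nM. Compound 4 is estimated at 50000 nM, between 15000 nM and 120000 nM.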

Compound 4, half-maximal inhibitory concentration: 150000 nM
Compound 4: the middle estimate sits 3.0-fold (0.48 log units) below what was measured, and the stated range ends below it.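

The step from compound 2 to compound 4 cannot be read in this assay, because compound 2 is recorded only as a limit: the limit of > 100000 nM in this assay, at which 2 of the 4 values shown sit.

The compounds shown leave open whether nitro in place of chloro, meta to a large group, shifts the number in the same direction as the same change para to a large group, which gave an at least 2.5-fold lower number from compound 1 to compound 3 (0.39 log units; beyond the scatter).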